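Tolerated concentration in cell culture across a trifluoromethyl benzimidazole pair

This account rests on a few compounds, and the source may have more. Where it says the series, first, only, none or still open, it means among the compounds named here.

Compound 1 `CN1CCN(CC(=O)Nc2ccc(-c3nc4cc(C(F)(F)F)ccc4n3C)cc2)CC1` is the better-tolerated of the two compounds measured in an ADME assay on MT4 cells (Homo sapiens) for cytotoxicity, read by MTT assay, with a stated time of 96 h; a higher number here means that more compound is tolerated, a lower number that less compound is tolerated: compound 1 gives 22000 nM, while compound 2 `O=[N+]([O-])c1ccc(-c2nc3cc(C(F)(F)F)ccc3[nH]2)c([N+](=O)[O-])c1` gives 9000 nM in this assay, a gap reported as beyond the scatter. Compound 2 differs from compound 1 in more than one place, so the two values are read only as two numbers, not as a step.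

Compound 3 `CCN(CC)CC(=O)Nc1ccc(-c2nc3cc(C(F)(F)F)ccc3n2C)cc1` has not yet been measured in this assay. Against compound 1 the counted difference is diethylamino in place of 4-methylpiperazin-1-yl on a saturated chain carbon bound to a carbonyl carbon. Within the data shown here, no measured pair in this set isolates that change, so its size is unknown. The amide, the core and the trifluoromethyl group are kept; only the terminal amine of the side chain is exchanged. For compound 3 the expected step from compound 1 is small, a 1.2-fold lower number from compound 1 to compound 3 (0.09 log units; within the scatter), with no direction claimed beyond the scatter. The estimate for compound 3 in this assay is therefore 18000 nM, within a range of 7000 nM to 45000 nM.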

Compound 3, half-maximal cytotoxic concentration: 9000 nM
Estimate against measurement, compound 3: 2.0-fold (0.30 log units) above; measured number inside the range.
By their numbers in this assay, from the lowest: compounds 2 and 3 (each within the scatter of the next); then compound 1.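

In this assay, among these compounds, the terminal amine on a saturated chain carbon bound to a carbonyl carbon is the first place where a single exchange can be read: diethylamino in place of 4-methylpiperazin-1-yl gives a 2.4-fold lower number from compound 1 to compound 3 (0.39 log units; beyond the scatter) with the amide, core and trifluoromethyl group kept. The step is modest but beyond the scatter, so the tolerated concentration does respond to the exchange at this position, and the open-chain amine carries the lower number. Nothing available explains the change.

The pair leaves open whether the step follows the ring itself or its second nitrogen; piperidin-1-yl or morpholin-4-yl at this place would separate the two. Also open, as far as these compounds go, is whether the same exchange on a longer chain gives a step of this size.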